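A few compounds are considered here, and "the series" means these few. Any claim that something is new, unique, unknown or untested is made for them only; others in the source may bear on it.

In an ADME assay on HepG2 cells (Homo sapiens) for cytotoxicity, read by MTT assay, with a stated time of 72 h (on this read-out higher numbers stand for lower toxicity in this test and lower numbers for higher toxicity in this test), compound 1 (`N#Cc1ccc(-c2cc(Cl)cn3c([N+](=O)[O-])c(CS(=O)(=O)c4ccccc4)nc23)cc1`) gives > 3900 nM as a limit. Compound 2 (`O=Cc1ccc(-c2cc(Cl)cn3c([N+](=O)[O-])c(CS(=O)(=O)c4ccccc4)nc23)cc1`) gives > 31200 nM as a limit, and no number places it. Compound 3 (`O=[N+]([O-])c1c(CS(=O)(=O)c2ccccc2)nc2c(-c3ccccc3F)cc(Cl)cn12`) gives > 3900 nM as a limit. Compound 4 (`O=[N+]([O-])c1c(CS(=O)(=O)c2ccccc2)nc2c(-c3ccc(F)cc3F)cc(Cl)cn12`) differs from compound 2 at one place: 2,4-difluorophenyl in place of 4-formylphenyl on an aromatic carbon. The closest measured change is a step that the two limits leave unreadable from compound 2 to compound 3 and it also removes 4-formylphenyl. Neither a step that the two limits leave unreadable from compound 1 to compound 3 nor a step that the two limits leave unreadable from compound 1 to compound 2 gives a size either. No change beyond the scatter is therefore expected in this assay, and the estimated step is an at least 1.5-fold lower number from compound 2 to compound 4 (0.19 log units; that floor lies within the scatter) on that basis. For compound 4 the expected value is 20000 nM with an estimated range from 4000 nM to 60000 nM for now.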

Compound 4, half-maximal cytotoxic concentration: > 7800 nM
Compound 4: only a limit was reported; the forecaster's own chance of this, stated with the estimate: 85%; the middle value is on the limit's open side.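

For the compounds shown here, compound 4, like compound 1, compound 2 and compound 3, carries only a limit in this assay, and no step among them can be read. The actual cytotoxic concentration of each of these compounds stays open.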